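The compounds below may be only part of what the source reports. "The series", "measured", "known", "first", "only" and "open" are said of these compounds alone.

Series notes. In a functional assay on A-375 cells (Homo sapiens) for inhibition, read by sulforhodamine B assay, with a stated time of 48 h (on this read-out lower numbers stand for stronger inhibition of growth and higher numbers for weaker inhibition of growth), compound 1 `COC(=O)c1sc2cc(-c3ccsc3)cnc2c1N` gives 12100 nM. Compound 2 `COC(=O)c1sc2cc(-c3ccc(C#N)cc3)cnc2c1N` returns in this assay only a limit, > 75000 nM, not a number; it sits at the limit of > 75000 nM in this assay, at which 1 of the 2 values shown sits. Compound 3 `COC(=O)c1sc2cc(-c3ccc(C(C)=O)cc3)cnc2c1N` carries acetyl in place of cyano on an aromatic carbon, acetyl in place of cyano on an aromatic carbon. Among the measured compounds shown here, no step between measured compounds is available for this kind of exchange, and compound 2 gives no firm number to start from, so no shift beyond the scatter is expected; the step from compound 2 to compound 3 is estimated at an at least 1.0-fold lower number from compound 2 to compound 3 (0.02 log units; that floor lies within the scatter), with a real chance that this assay again reports only a limit. For compound 3 the expected value is 70000 nM, with a range of 20000 nM to 250000 nM.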

Compound 3, concentration for 50% growth inhibition: > 150000 nM
Compound 3: no number, only a limit; the forecaster's own chance of this, stated with the estimate: 55%; middle value at least 2.1-fold (0.33 log units) away from the limit.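

Compound 2 and compound 3 both return only limits in this assay, and no step can be read between them. Left open is whether acetyl in place of cyano on an aromatic carbon shifts the read-out in this assay at all.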